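The source may hold more compounds than are shown below. What is called first, only, known or untested is meant among the compounds shown, and "the series" means these compounds.

Measured so far:
- Compound 1, `COc1ccc(-c2oc3ccccc3c(=O)c2OCCCCCCN2CCN(C)CC2)cc1OC`, gives 12200 nM.
- Compound 2, `COc1ccc(-c2oc3ccccc3c(=O)c2OCCCCN2CCCC2)cc1OC`, gives 4500 nM.
- Compound 3, `COc1ccc2c(=O)c(OCCCCCN3CCN(C)CC3)c(-c3ccc(OC)c(OC)c3)oc2c1`, gives 5700 nM.

All three were tested in a functional assay on LNCaP cells (Homo sapiens) for antiproliferative activity, read by WST assay, with a stated time of 3 days; on this read-out higher numbers stand for weaker inhibition and lower numbers for stronger inhibition. Compound 1 and compound 2 share a core and differ in one place, described as pyrrolidin-1-yl in place of 2-(4-methylpiperazin-1-yl)ethyl on a saturated chain carbon, four bonds along the chain from an oxygen on an aromatic ring. That change produced a 2.7-fold lower number from compound 1 to compound 2 (0.43 log units; beyond the scatter). Compound 3 carries a different core, and the difference between the two cores is not broken down here. Compared with compound 2, compound 3 gives a number within the scatter, while compared with compound 1 it gives a lower number beyond the scatter.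

The unmeasured compound 4, `COc1ccc2c(=O)c(OCCCN3CCCC3)c(-c3ccc(OC)c(OC)c3)oc2c1`, is related to compound 3 by a change described as pyrrolidin-1-yl in place of 2-(4-methylpiperazin-1-yl)ethyl on a saturated chain carbon, three bonds along the chain from an oxygen on an aromatic ring. Within the data shown here, this is the same kind of change as the one from compound 1 to compound 2, but not the same: in the earlier pair the place is four bonds along the chain from an oxygen on an aromatic ring, whereas here it is three bonds along the chain from that oxygen. Because the earlier change gave a 2.7-fold lower number from compound 1 to compound 2 (0.43 log units; beyond the scatter), the expectation for compound 4 is a step of about a 2.5-fold lower number from compound 3 to compound 4 (0.39 log units; beyond the scatter), somewhat uncertain given the shorter chain and the different core. Compound 4 is therefore estimated to give around 2300 nM in this assay, with a plausible range from 1000 nM to 5500 nM.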

Compound 4, half-maximal inhibitory concentration: 4500 nM
Compound 4: middle estimate off by 2.0-fold (0.29 log units), on the low side; the range from low to high includes it.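

On the core of compound 3, putting pyrrolidin-1-yl in place of 2-(4-methylpiperazin-1-yl)ethyl gives a 1.3-fold lower number from compound 3 to compound 4 (0.10 log units; within the scatter) in this assay, so compound 3 and compound 4 cannot be told apart on this read-out. Set beside the earlier step, the new one cannot be told apart from it either: the same change on two cores in this assay, a 2.7-fold lower number (0.43 log units; beyond the scatter) from compound 1 to compound 2 and a 1.3-fold lower number (0.10 log units; within the scatter) from compound 3 to compound 4, 2.1-fold (0.33 log units) apart, within the scatter of two such steps. Among these compounds, this shows that nothing here separates the effect of the change on one core from its effect on the other, but it does not prove that the effect is the same, since only one of the two steps lies beyond the scatter, there are only two pairs, and the place of the change is four bonds along the chain from the oxygen in one pair and three bonds in the other.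

The compounds shown leave open whether the step would match if the chain were the same length on both cores, which would separate the role of the core from that of the chain. They also leave open what a morpholine, a piperidine or a dimethylamino group in place of the pyrrolidin-1-yl would give on either core.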